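Swapping the hydroxyphenyl for a fluorophenyl on the chain

The source may hold more compounds than are shown below. What is called first, only, known or untested is meant among the compounds shown, and "the series" means these compounds.

Measured so far in a functional assay on HeLa cells (Homo sapiens) for cytotoxicity, read by WST assay, with a stated time of 48 h; on this read-out higher numbers stand for weaker inhibition and lower numbers for stronger inhibition:
compound 1, `Oc1cccc(/C=C/C[C@H]2C[C@@H]([C@@H](O)c3ccccc3)CO[C@@H]2c2ccccc2)c1`, gives 18600 nM;
compound 2, `COc1ccc(/C=C/C[C@@H]2C[C@H]([C@H](O)c3ccc(OC)c(OC)c3)CO[C@H]2c2ccc(OC)c(OC)c2)cc1OC`, gives 28700 nM;
compound 3, `COc1ccc(/C=C/C[C@@H]2C[C@@H]([C@@H](OC)c3ccc(OC)c(OC)c3)CO[C@H]2c2ccc(OC)c(OC)c2)cc1OC`, gives only a limit of the assay, > 100000 nM.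

Compound 1 and compound 2 sit within the usual scatter of each other in this assay, so nothing separates them. Among the compounds with values here, compound 3 stands apart only in that its value is a limit, (the limit of > 100000 nM in this assay, at which 1 of the 3 values shown sits), and no step between it and the others is counted. Within the data shown here, no two measured compounds differ in one place, so no measured step is available to lean on.

Compound 4, `O[C@@H](c1ccccc1)[C@H]1CO[C@H](c2ccccc2)[C@@H](C/C=C/c2ccccc2F)C1`, is not yet measured. It differs from compound 1 in one place: 2-fluorophenyl in place of 3-hydroxyphenyl on a double-bonded chain carbon bound to a double-bonded chain carbon.

Without a measured step of the same kind, the expected change is taken as modest and towards a higher number. Compound 4 is expected to give about 30000 nM in this assay, likely between 10000 nM and 100000 nM, which means an estimated step of a 1.6-fold higher number from compound 1 to compound 4 (0.21 log units; within the scatter).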

Compound 4, half-maximal inhibitory concentration: 9730 nM
For compound 4 the middle estimate is 3.1-fold (0.49 log units) above the measured one; the whole stated range lies above it.
By their numbers in this assay, from the lowest: compounds 4, 1 and 2 (each within the scatter of the next, the first and the last beyond it). At a limit, above all of these: compound 3.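

Within the data shown here, a step of a 1.9-fold lower number from compound 1 to compound 4 (0.28 log units; within the scatter) in this assay is the first reading of a change in one place. On a double-bonded chain carbon bound to a double-bonded chain carbon, 2-fluorophenyl and 3-hydroxyphenyl cannot be told apart in this assay, even though the entering group has no hydrogen-bond donor or acceptor and the leaving group has one of each. Nothing measured here accounts for this result.

This single swap does not show whether the hydroxyl and the fluorine each matter on their own, or whether the same holds on other versions of the core. It also leaves open how an unsubstituted phenyl, an amine or a carboxylic acid on that ring, or a longer chain carrying the ring would read at this position.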